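The source may hold more compounds than are shown below. What is called first, only, known or untested is meant among the compounds shown, and "the series" means these compounds.

Of the compounds shown here, three sharing one core have been tested so far in a functional assay on NCI-H460 cells (Homo sapiens); on this read-out higher numbers stand for an effect only at larger amounts of compound and lower numbers for an effect already at smaller amounts. Compound 1 `COc1cc(C2OC(c3ccc(N(C)C)cc3)=NN2C(C)=O)cc(OC)c1OC` gives 0.044 uM, the lowest number of the three and clearly apart from the other two. Compound 2 `COc1cc(C2OC(c3cccc(N(C)C)c3)=NN2C(C)=O)cc(OC)c1OC` gives 0.26 uM. It carries 3-(dimethylamino)phenyl in place of 4-(dimethylamino)phenyl, and this makes a 5.9-fold higher number from compound 1 to compound 2 (0.77 log units; beyond the scatter). Compound 3 `COc1cc(C2OC(c3ccc(N(C)C)cc3)=NN2C(C)=O)cc(OC)c1OC(C)=O` gives 13 uM. It has acetyl in place of methyl on an oxygen on an aromatic ring, and this makes a 300-fold higher number from compound 1 to compound 3 (2.47 log units; beyond the scatter).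

Compound 4 `CCOC(=O)C(=O)N1N=C(c2ccc(N(C)C)cc2)OC1c1cc(OC)c(OC)c(OC)c1` has not been measured yet. It differs from compound 1 as follows: ethoxycarbonyl in place of methyl on a carbonyl carbon. In words, ethoxycarbonyl stands in place of methyl on a carbonyl carbon, so acetyl becomes (ethoxycarbonyl)carbonyl. Neither measured step touches this place, so they offer only indirect guidance. For the measured compounds named here, still, compound 1 at 0.044 uM holds the lowest number so far, and each change away from it has raised the number. A rise in this assay is therefore expected, closer in size to the modest step to compound 2 than to the large one to compound 3. The expected change is a 4.5-fold higher number from compound 1 to compound 4 (0.66 log units; beyond the scatter), with considerable uncertainty. For compound 4 the estimated value is 0.2 uM, within an expected range from 0.03 uM to 1.5 uM.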

Compound 4, concentration for half-maximal effect: 33 uM
Estimate against measurement, compound 4: 170-fold (2.22 log units) below; measured number above the stated range.
By their numbers in this assay, from the lowest: compound 1; then compound 2; then compound 3; then compound 4.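

In this assay, the carbonyl carbon on the amide-type nitrogen in a ring proves to be a place where one change can matter greatly: ethoxycarbonyl in place of methyl gives a 750-fold higher number from compound 1 to compound 4 (2.88 log units; beyond the scatter). For the compounds shown here, the earlier steps changed other places, so this is the first sign that the acetyl group cannot be swapped freely for (ethoxycarbonyl)carbonyl, a change that brings 5 heavy atoms where methyl had 1, along with 2 hydrogen-bond acceptors where methyl had none. Nothing available here explains why this step is so large.

From the compounds shown here alone, with only one replacement at this place, it remains open whether the rise comes with the greater length of the new group or with the ester it contains, and a simple ethyl or propyl group on the same carbonyl carbon, set beside a carboxylic acid there, would help to tell these two readings apart. Going by these compounds, it is also open whether the same change would have a similar effect alongside 3-(dimethylamino)phenyl, the group carried by compound 2.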